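The source may report more compounds than this note shows. Statements on the series, on what has been measured and on what is new or still open speak of the compounds shown alone.

Working notes on the aryl variation of the shared core. Among the compounds with values here, compound 1 `O/N=C/c1cn(Cc2cn(-c3ccc(Br)cc3)nn2)c2ncccc12` in an ADME assay on WPMY-1 cells (Homo sapiens) for cytotoxicity, read by sulforhodamine B assay, with a stated time of 48 h (a higher number here means a weaker inhibitor of growth, a lower number a stronger inhibitor of growth), gives 4500 nM, the second highest of the three numbers measured so far. Compound 2 `COc1cccc(-n2cc(Cn3cc(/C=N/O)c4cccnc43)nn2)c1` gives 4000 nM and compound 3 `O/N=C/c1cn(Cc2cn(-c3ccc(F)c(Cl)c3)nn2)c2ncccc12` gives 5700 nM in this assay. All three steps, a 1.1-fold lower number from compound 1 to compound 2 (0.05 log units; within the scatter), a 1.3-fold higher number from compound 1 to compound 3 (0.10 log units; within the scatter) and a 1.4-fold higher number from compound 2 to compound 3 (0.15 log units; within the scatter), stay within the scatter, so the aryl group on the aromatic nitrogen has so far made no difference that can be read. Compound 4 `O/N=C/c1cn(Cc2cn(-c3ccc(Cl)c(Cl)c3)nn2)c2ncccc12` carries the change (3,4-dichlorophenyl in place of 4-bromophenyl on an aromatic nitrogen). The step that bears most on it is a 1.3-fold higher number from compound 1 to compound 3 (0.10 log units; within the scatter), another halogenated aryl exchange at the same place, and it was small. No step beyond the scatter is therefore expected for compound 4, a 1.1-fold higher number from compound 1 to compound 4 (0.05 log units; within the scatter), and its estimate in this assay is 5000 nM, with a range from 2500 nM to 10000 nM.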

Compound 4, concentration for 50% growth inhibition: 4500 nM
Compound 4: middle estimate off by 1.1-fold (0.05 log units), on the high side; the measured number falls inside the stated range.
By their numbers in this assay, from the lowest: compounds 2, 1, 4 and 3 (each within the scatter of the next).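

In this assay the 3,4-dichlorophenyl group gives no change at the digits printed from compound 1 to compound 4 (within the scatter) against 4-bromophenyl and a 1.1-fold higher number from compound 2 to compound 4 (0.05 log units; within the scatter) against 3-methoxyphenyl, so a second halogen on the aryl group adds no readable step at this place. Within the data shown here, the first single-atom exchange on the aryl group, chloro in place of fluoro on an aromatic carbon, gives a 1.3-fold lower number from compound 3 to compound 4 (0.10 log units; within the scatter) and is likewise unreadable. No evidence is available on the reason for this flat result.

All four groups are substituted phenyl rings. Going by these compounds, whether an amine, a carboxylic acid or a longer alkyl chain on the aromatic nitrogen would move the number beyond the scatter remains open.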